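Adding a Second Trifluoromethyl to the Urea Aryl Group

This account rests on a few compounds, and the source may have more. Where it says the series, first, only, none or still open, it means among the compounds named here.

Within the data shown here, compound 1 `COc1cc(Cl)cc(-c2nn(-c3cccc(NC(=O)Nc4cccc(C(F)(F)F)c4)c3)cc2-c2ccncc2)c1` is one of two compounds measured in a functional assay on CCRF-CEM cells (Homo sapiens) for inhibition, read by sulforhodamine B assay, with a stated time of 48 h, tested at 100 uM; on this read-out higher numbers stand for a weaker effect at the one concentration tested and lower numbers for a stronger effect. In this assay compound 1 gives -18%, the highest of the two numbers. Its nearest neighbour is compound 2 `COc1cc(Cl)cc(-c2nn(-c3cccc(NC(=O)Nc4ccc(Cl)c(Cl)c4)c3)cc2-c2ccncc2)c1`, which in this assay gives -27%; the two differ only in the aryl group on the amide-type nitrogen, 3,4-dichlorophenyl in place of 3-(trifluoromethyl)phenyl, and that step is a number 9 percentage points lower from compound 1 to compound 2 (within the scatter), so the two values cannot be told apart.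

Compound 3 `COc1cc(Cl)cc(-c2nn(-c3cccc(NC(=O)Nc4cc(C(F)(F)F)cc(C(F)(F)F)c4)c3)cc2-c2ccncc2)c1` is not yet measured. It differs from compound 1 by trifluoromethyl in place of hydrogen on an aromatic carbon, on an aromatic carbon of the six-membered carbon ring, meta to a large group and meta to the trifluoromethyl group already present. Among the measured compounds shown here, the only measured step that bears on it is the exchange of the aryl group on that same nitrogen from compound 1 to compound 2, and that step stayed within the scatter. On that basis compound 3 is expected to sit close to compound 1, with a step of a number 6 percentage points lower from compound 1 to compound 3 (within the scatter) that is not expected to exceed the scatter. The estimate for compound 3 in this assay is -24%, within -45% to 0%.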

Compound 3, a percentage reported as activity, at one concentration (the size of the read-out at that concentration, not a potency): -29%
Estimate against measurement, compound 3: 5 percentage points above, and the stated range covers the measured number.
By their numbers in this assay, from the lowest: compounds 3, 2 and 1 (each within the scatter of the next, the first and the last beyond it).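

Compound 3 carries a second trifluoromethyl on the urea aryl group, on an aromatic carbon meta to a large group and meta to the trifluoromethyl group already present, and in this assay this exchange of hydrogen for trifluoromethyl gives a number 11 percentage points lower from compound 1 to compound 3 (beyond the scatter) and so marks a stronger effect at the concentration tested. It is the only step shown that goes beyond the scatter, whereas the exchange of the whole aryl group on the same nitrogen did not, so this aromatic carbon is a place where a substituent can move the number, although the step is modest and rests on a single pair of compounds. Nothing measured here accounts for the step.

The compounds shown leave open whether trifluoromethyl itself matters at this place or whether a methyl, a methoxy group, an amine or a carboxylic acid on the same carbon would give a similar number. Also open, on these data alone, is how this step would appear as a potency; the read-out covers a single concentration and gives the size of the effect there.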